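Working notes on cytotoxicity for compounds 1 to 3

A few compounds are considered here, and "the series" means these few. Any claim that something is new, unique, unknown or untested is made for them only; others in the source may bear on it.

Compound 1 `CS(=O)(=O)Nc1ccc2c(c1)S(=O)(=O)N=C(c1c(O)c(-c3ccsc3)nn(CCC3CC3)c1=O)N2` and compound 2 `CC(C)(C)CCn1nc(-c2cccs2)c(O)c(C2=NS(=O)(=O)c3cc(NS(C)(=O)=O)ccc3N2)c1=O` share a core and were both run in an ADME assay on Huh-7 cells (Homo sapiens) for cytotoxicity, with a stated time of 72 h; on this read-out lower numbers stand for higher toxicity in this test and higher numbers for lower toxicity in this test. Compound 1 reaches only the limit of the test, > 1000 nM. Compound 2 likewise returns only the limit, > 1000 nM. Both results therefore rest on (the limit of > 1000 nM in this assay, at which 2 of the 2 values shown sit), so neither compound is placed on a numerical scale, and compound 2 stands with compound 1 at that limit with no order between them. Going by the values given here, no step between measured compounds is available. Compound 3 `CS(=O)(=O)Nc1ccc2c(c1)S(=O)(=O)N=C(c1c(O)c(-c3cccs3)nn(Cc3ccccn3)c1=O)N2` is the next compound to be measured in this assay. It differs from compound 2 by pyridin-2-yl in place of neopentyl on a saturated chain carbon bound to an aromatic nitrogen. With both measured compounds at the limit, no step beyond the usual scatter is expected, and a limit is again the likeliest outcome. The estimate for compound 3 is 1500 nM, within 600 nM to 6000 nM. The expected step is a step that the limit leaves unreadable from compound 2 to compound 3, none beyond the scatter.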

Compound 3, half-maximal cytotoxic concentration: > 1000 nM
Compound 3 gave a limit, no number; the forecaster's own chance of this, stated with the estimate: 80%; the middle value does not contradict the limit.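

No step can be read from compound 2 to compound 3, since both return only a limit: the limit of > 1000 nM in this assay, at which 3 of the 3 values shown sit. The compounds shown leave open whether pyridin-2-yl in place of neopentyl changes the half-maximal cytotoxic concentration at all, and where any of the three compounds falls on a numerical scale.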